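A few compounds are considered here, and "the series" means these few. Any claim that something is new, unique, unknown or untested is made for them only; others in the source may bear on it.

Of the compounds shown here, three built on one shared core have been measured in a functional assay on NCI-H226 cells (Homo sapiens) for inhibition, read by sulforhodamine B assay, with a stated time of 48 h; a lower number here means that less compound is tolerated, a higher number that more compound is tolerated. Compound 1 `COc1cc(-c2nn(-c3cccc(NC(=O)Nc4cc(C(F)(F)F)cc(C(F)(F)F)c4)c3)cc2-c2ccncc2)ccc1Cl` reaches only a limit there, > 50000 nM. Compound 2 `COc1cc(-c2nn(-c3cccc(NC(=O)c4cccc(C(F)(F)F)c4)c3)cc2-c2ccncc2)ccc1Cl` likewise gives a limit, > 50000 nM. Compound 3 `COc1cc(-c2nn(-c3cccc(NC(=O)Nc4ccc(Cl)c(Cl)c4)c3)cc2-c2ccncc2)ccc1Cl` also stands at a limit, > 50000 nM. Since all three values are limits, compound 3 cannot be set apart from compound 1 or compound 2 on these numbers. For the measured compounds named here, the one step that can be traced, a step that the two limits leave unreadable from compound 2 to compound 3, remains unreadable because of the limit of > 50000 nM in this assay, at which 3 of the 3 values shown sit, at which every value shown sits. Compound 4 `COc1cc(-c2nn(-c3cccc(NC(=O)Nc4cccc(C(F)(F)F)c4)c3)cc2-c2ccncc2)ccc1Cl` differs from compound 3 by 3-(trifluoromethyl)phenyl in place of 3,4-dichlorophenyl on an amide-type nitrogen. Compound 1 and compound 3 already carry two differently substituted rings on that amide-type nitrogen and both stay at the limit; compound 2 holds the 3-(trifluoromethyl)phenyl directly on the carbonyl carbon and does the same. The expected change in this assay from this exchange is therefore a number no higher from compound 3 to compound 4 (the limit leaves the size open), that is, no reading beyond the limit. Compound 4 is estimated at 50000 nM, within 25000 nM to 200000 nM.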

Compound 4, concentration lethal to 50% of the cells: > 50000 nM
Compound 4: a limit, no number; the forecaster's own chance of this, stated with the estimate: 85%; the middle value sits exactly at the limit.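

In this assay compound 4 gives > 50000 nM, which is a limit, and no step linking compound 4 with compound 1, compound 2 or compound 3 can be read because of this shared ceiling: the limit of > 50000 nM in this assay, at which 4 of the 4 values shown sit.

The compounds shown leave open where any of the four actually lies, and whether any change on the shared core would give a number.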